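Swapping 4-cyanophenyl for 3-nitrophenyl in a small series

This account rests on a few compounds, and the source may have more. Where it says the series, first, only, none or still open, it means among the compounds named here.

Compound 1 `CNC(=O)c1cc(Oc2ccc(C(=O)/C=C/c3ccco3)cc2)ccn1`: "not determined" (no result reported)
Compound 2 `CNC(=O)c1cc(Oc2ccc(C(=O)/C=C/c3ccc(Br)cc3)cc2)ccn1`: > 50000 nM
Compound 3 `CNC(=O)c1cc(Oc2ccc(C(=O)/C=C/c3ccc(C#N)cc3)cc2)ccn1`: 5430 nM

Among the measured compounds shown here, in a functional assay on HepG2 cells (Homo sapiens) for cytotoxicity, read by MTT assay, with a stated time of 72 h (a higher number here means a weaker inhibitor, a lower number a stronger inhibitor), compound 3 gives 5430 nM, the only true number so far. Compound 2 gives > 50000 nM, which is a limit of the assay and not a number. Compound 1 has no result and adds nothing here.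

Compound 4 `CNC(=O)c1cc(Oc2ccc(C(=O)/C=C/c3cccc([N+](=O)[O-])c3)cc2)ccn1` is still to be measured. The change is 3-nitrophenyl in place of 4-cyanophenyl on a double-bonded chain carbon bound to a double-bonded chain carbon.

For the measured compounds named here, only one measured step bears on this: an at least 9.2-fold lower number from compound 2 to compound 3 (0.96 log units; beyond the scatter), with cyano in place of bromo on an aromatic carbon. On these data alone, its full size is unknown, since it starts from the limit of > 50000 nM in this assay, at which 1 of the 3 values shown sits. It does show that swapping a single group can move the number well beyond the scatter. Going by the values given here, the only other measured neighbour lies on the weaker side of compound 3 at 5430 nM, so a higher number is the likelier direction. The expected change is small and not clearly beyond the scatter: a 1.8-fold higher number from compound 3 to compound 4 (0.27 log units; within the scatter). For compound 4 the estimated value is 10000 nM, with an expected range from 3000 nM to 40000 nM.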

Compound 4, half-maximal inhibitory concentration: > 50000 nM
Compound 4 gave a limit, no number; the forecaster's own chance of this, stated with the estimate: 25%; middle value at least 5.0-fold (0.69 log units) from the limit.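

In this assay, among the compounds shown here, the group on the double-bonded chain carbon proves sensitive in a second swap, and this time the number moves away from the only true value: 3-nitrophenyl in place of 4-cyanophenyl gives an at least 9.2-fold higher number from compound 3 to compound 4 (0.96 log units; beyond the scatter). Together with the earlier step, an at least 9.2-fold lower number from compound 2 to compound 3 (0.96 log units; beyond the scatter), this leaves 4-cyanophenyl as the only group shown here with a true number, as both steps that reach it from a limit lie beyond the scatter. The step between compound 2 and compound 4 cannot be read, and the 4-bromophenyl and 3-nitrophenyl groups cannot be ranked against each other, because each of these compounds gives a limit and not a number: the limit of > 50000 nM in this assay, at which 2 of the 4 values shown sit.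

This swap changes the substituent and its place on the ring together, so the compounds shown cannot separate the nitrile from its position, and a 3-cyanophenyl or a 4-nitrophenyl group would be needed to pull the two apart. They also leave open whether a different group at this place, such as a 4-aminophenyl or a 4-carboxyphenyl, would give a true number at all.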